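A Single Methyl Added to the Butyl Chain

The source may hold more compounds than are shown below. What is called first, only, known or untested is meant among the compounds shown, and "the series" means these compounds.

In a functional assay on ACHN cells (Homo sapiens) for antiproliferative activity, read by sulforhodamine B assay (a higher number here means a weaker inhibitor of growth, a lower number a stronger inhibitor of growth), compound 3 `CCCCOc1cccc(O)c1C(=O)/C=C/c1ccc(O)cc1` reaches only a limit, > 30000 nM. Compound 2 `CC(C)=CCOc1cccc(O)c1C(=O)/C=C/c1ccc(O)cc1` also stands at a limit, > 30000 nM. Compound 1 `CC(C)(C)CCOc1cccc(O)c1C(=O)/C=C/c1ccc(O)cc1` gives a true number, 3140 nM. Compound 4 `CC(C)CCOc1cccc(O)c1C(=O)/C=C/c1ccc(O)cc1` changes the chain of compound 3 by methyl in place of hydrogen on a saturated chain carbon bound to two saturated chain carbons, taking butyl to isopentyl. The nearest measured guide is an at least 9.5-fold higher number from compound 1 to compound 3 (0.98 log units; beyond the scatter), and an at least 9.5-fold higher number from compound 1 to compound 2 (0.98 log units; beyond the scatter) is a similar step. The chain of compound 4 carries more branching than that of compound 3 and less than that of compound 1, so only part of that gain in strength is expected. The expected step is an at least 2.5-fold lower number from compound 3 to compound 4 (0.39 log units; beyond the scatter). For compound 4 the estimate is 12000 nM, with an expected range of 4000 nM to 30000 nM.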

Compound 4, concentration for 50% growth inhibition: 11300 nM
Compound 4: the middle estimate sits 1.1-fold (0.03 log units) above what was measured; low and high end bracket the measured number.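

In this assay, one added methyl on the butyl chain is enough to give a true number (an at least 2.6-fold lower number from compound 3 to compound 4 (0.42 log units; beyond the scatter)), so the full branching of compound 1 is not needed for measurable growth inhibition. The saturated isopentyl chain also outdoes the unsaturated chain of compound 2 (an at least 2.6-fold lower number from compound 2 to compound 4 (0.42 log units; beyond the scatter)). Removing the further methyl of compound 1 still costs strength (a 3.6-fold higher number from compound 1 to compound 4 (0.56 log units; beyond the scatter)), so the single branch captures only part of the gain.

The steps from compound 2 and compound 3 remain minimum sizes because both start from a limit: the limit of > 30000 nM in this assay, at which 2 of the 4 values shown sit. From the compounds shown here alone, whether a longer chain or an amine at the chain end would change growth inhibition remains open.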